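Aryl exchange on the shared core: compound 3 to compound 4

This account rests on a few compounds, and the source may have more. Where it says the series, first, only, none or still open, it means among the compounds named here.

Measured in a functional assay on HT-1080 cells (Homo sapiens) for cytotoxicity, read by MTT assay, with a stated time of 72 h; a higher number here means a weaker inhibitor, a lower number a stronger inhibitor:
compound 1 `COc1cccc(/C=C2\CCC/C(=C\c3ccc(Br)cc3)C2=O)c1OC`: 13700 nM
compound 2 `COc1cccc(/C=C2\CCC/C(=C\c3cccc(OC)c3OC)C2=O)c1`: 9900 nM
compound 3 `COc1cccc(/C=C2\CCC/C(=C\c3ccc(Cl)cc3Cl)C2=O)c1OC`: > 20000 nM (a limit)

Compound 3 stands only at a limit, > 20000 nM, and not at a number. Compound 4 `COc1cc(/C=C2\CCC/C(=C\c3cccc(OC)c3OC)C2=O)ccc1O` has 4-hydroxy-3-methoxyphenyl in place of 2,4-dichlorophenyl on a double-bonded chain carbon bound to a double-bonded ring carbon. Among the compounds with values here, three measured steps bear on this place: a 1.4-fold lower number from compound 1 to compound 2 (0.14 log units; within the scatter), an at least 1.4-fold higher number from compound 1 to compound 3 (0.16 log units; that floor lies within the scatter) and an at least 2.0-fold higher number from compound 2 to compound 3 (0.30 log units; that floor lies within the scatter). Read in reverse, the last step points to a lower number on leaving 2,4-dichlorophenyl. Compound 2, at 9900 nM, anchors the expectation. The expected step in this assay, a modest fall, is an at least 2.5-fold lower number from compound 3 to compound 4 (0.39 log units; beyond the scatter). The estimate for compound 4 is 8000 nM, with an expected range of 2500 nM to 20000 nM.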

Compound 4, half-maximal inhibitory concentration: 5900 nM
Estimate against measurement, compound 4: 1.4-fold (0.13 log units) above, within the range that was stated.
By their numbers in this assay, from the lowest: compounds 4, 2 and 1 (each within the scatter of the next, the first and the last beyond it). At a limit, above all of these: compound 3.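

With 4-hydroxy-3-methoxyphenyl at this place, the series gains a fully measured step beyond the scatter, a 2.3-fold lower number from compound 1 to compound 4 (0.37 log units; beyond the scatter), and leaving 2,4-dichlorophenyl gives an at least 3.3-fold lower number from compound 3 to compound 4 (0.53 log units; beyond the scatter). Hydroxy in place of hydrogen on an aromatic carbon gives only a 1.7-fold lower number from compound 2 to compound 4 (0.22 log units; within the scatter), so that single change is not resolved. The step from compound 3 is a floor only, because compound 3 stands at a limit: the limit of > 20000 nM in this assay, at which 1 of the 4 values shown sits.

Still open, as far as these compounds go, is whether an amine or a carboxylic acid on this aryl ring, in place of the hydroxy, would shift the number beyond the scatter.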